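Fluorine for Methyl on the Anilide of a Sulfamide Series

The source may hold more compounds than are shown below. What is called first, only, known or untested is meant among the compounds shown, and "the series" means these compounds.

For the measured compounds named here, compound 1 `Cc1ccc(NC(=O)CN2CCN(S(=O)(=O)N3CCC(C)CC3)CC2)cc1` is one of two compounds measured in an assay on HEK293 cells for activation of potassium channel subfamily T member 1 (Homo sapiens), read by thallium flux (a higher number here means that more compound is needed for the effect, a lower number that less compound is needed), where compound 1 gives 4100 nM. Compound 2 `COc1ccc(Cl)cc1NC(=O)CC1CCN(S(=O)(=O)N2CCC(C)CC2)CC1` gives 9300 nM in this assay, and compound 1 therefore has the lower of the two numbers, by a margin beyond the usual scatter. Compound 3 `CC1CCN(S(=O)(=O)N2CCN(CC(=O)Nc3cccc(F)c3)CC2)CC1` differs from compound 1 in one place: 3-fluorophenyl in place of 4-methylphenyl on an amide-type nitrogen. Going by the values given here, no measured pair shows this change, so only a modest step, if any beyond the scatter, is expected; the step of a 1.3-fold higher number from compound 1 to compound 3 (0.13 log units; within the scatter) is estimated as a slight rise. Compound 3 is expected to give 5500 nM, in the range 2000 nM to 15000 nM.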

Compound 3, half-maximal effective concentration: 4600 nM
Compound 3: the middle estimate sits 1.2-fold (0.08 log units) above what was measured; the measured number falls inside the stated range.
By their numbers in this assay, from the lowest: compounds 1 and 3 (each within the scatter of the next); then compound 2.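

Replacing 4-methylphenyl with 3-fluorophenyl on an amide-type nitrogen leaves the reading in this assay within the scatter (a 1.1-fold higher number from compound 1 to compound 3 (0.05 log units; within the scatter)). This position therefore accepts this exchange of groups with no measurable penalty, which compound 1 and compound 2 alone could not show, since they differ in more than one place. No measurement here bears on why the two groups read alike.

On these data alone, whether a trifluoromethyl or a carboxylic acid on the same phenyl would also read alike remains open. So does whether this exchange would give the same result on the core of compound 2.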